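Swapping isobutyl for methyl in a two-compound series

The source may report more compounds than this note shows. Statements on the series, on what has been measured and on what is new or still open speak of the compounds shown alone.

Measured so far in an ADME assay on microsomes from liver (Mus musculus) for metabolic stability, read by LC-MS, using NADPH, with stated times of 15 min and 60 min, tested at 4.6 uM (on this read-out lower numbers stand for a shorter-lived compound and higher numbers for a longer-lived compound), for each compound
compound 1 `CN1CCC(c2ccc3c(c2)oc(=O)n3C(=O)NCCCCc2ccc(F)cc2)CC1` gives 0.5 h
compound 2 `CC(C)CN1CCC(c2ccc3c(c2)oc(=O)n3C(=O)NCCCCc2ccccc2)CC1` gives 1 h

Only these two readings exist, and compound 2 at 1 h lies within the usual scatter of compound 1, so the pair sets no order. Within the data shown here, no measured pair differs in one place only, which leaves no direct reading of the group in question.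

Compound 3 `CN1CCC(c2ccc3c(c2)oc(=O)n3C(=O)NCCCCc2ccccc2)CC1` has not yet been measured. It departs from compound 2 by hydrogen in place of isopropyl on a saturated chain carbon bound to an amine nitrogen in a ring, so that isobutyl becomes methyl.

Compound 1 also carries 1-methylpiperidin-4-yl and gives 0.5 h on this measure. Resting on that single value, a small move in this assay towards a shorter half-life is expected, none of it beyond the scatter. The estimated step is a 1.7-fold lower number from compound 2 to compound 3 (0.22 log units; within the scatter) in this direction. Compound 3 is estimated at 0.6 h with an expected range from 0.25 h to 1.2 h on this measure.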

Compound 3, half-life: 0.667 h
Compound 3: the middle estimate sits 1.1-fold (0.05 log units) below what was measured, within the range that was stated.
By their numbers in this assay, from the lowest: compounds 1, 3 and 2 (each within the scatter of the next).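

In this assay the change from isobutyl to methyl now has a direct reading: a 1.5-fold lower number from compound 2 to compound 3 (0.18 log units; within the scatter) stays within the scatter, so hydrogen in place of isopropyl on a saturated chain carbon bound to an amine nitrogen in a ring shows no clear effect on half-life in this pair. A second direct reading, a 1.3-fold higher number from compound 1 to compound 3 (0.13 log units; within the scatter) for hydrogen in place of fluoro on an aromatic carbon, also stays within the scatter, so neither of the two single changes separates its pair on this measure. No measurement at hand accounts for these readings.

From the compounds shown here alone, each change rests on one pair, so it remains open whether the same steps would hold on a different background, or whether a larger group such as benzyl or cyclopropylmethyl in place of isobutyl would move the half-life beyond the scatter. Going by these compounds, it is equally open how chloro or methoxy in place of fluoro, or a shorter chain in place of the butyl chain, would read in this assay on this core.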